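The source may hold more compounds than are shown below. What is called first, only, known or untested is meant among the compounds shown, and "the series" means these compounds.

Measured compounds:
Compound 1 `Cc1ccc2c(=O)c(CSC(=S)N(C(C)C)C(C)C)coc2c1`: in a functional assay on SW480 cells (Homo sapiens) for antiproliferative activity, read by MTT assay, with a stated time of 72 h (a higher number here means a weaker inhibitor, a lower number a stronger inhibitor), compound 1 gives only a limit, > 25000 nM.
Compound 2 `O=c1c(CSC(=S)N2CCOCC2)coc2ccccc12`: in this assay compound 2 gives 5900 nM.

Among the compounds with values here, compound 2 thus holds the only true number recorded in this assay; the other entry sits at a limit (the limit of > 25000 nM in this assay, at which 1 of the 2 values shown sits). Compound 3 `Cc1ccc2c(=O)c(CSC(=S)N3CCOCC3)coc2c1` differs from compound 2 by methyl in place of hydrogen on an aromatic carbon. Within the data shown here, no measured pair isolates this change, as compound 1 carries the methyl but also a different amine part, so its limit cannot be read against compound 2. The step of a 1.2-fold higher number from compound 2 to compound 3 (0.07 log units; within the scatter) is expected to stay within the usual scatter. For compound 3 in this assay the estimate is 7000 nM, with a range from 2500 nM to 25000 nM.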

Compound 3, half-maximal inhibitory concentration: 3800 nM
Estimate against measurement, compound 3: 1.8-fold (0.27 log units) above; the range from low to high includes it.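

On the aromatic carbon, methyl in place of hydrogen, now isolated in a single pair, gives a 1.6-fold lower number from compound 2 to compound 3 (0.19 log units; within the scatter) in this assay and so stays within the scatter. With the methyl present in both compounds, morpholin-4-yl in place of diisopropylamino on a thiocarbonyl carbon gives an at least 6.5-fold lower number from compound 1 to compound 3 (0.81 log units; beyond the scatter) and is the change that stands beyond the scatter. That step is only a bound, because compound 1 stands at a limit: the limit of > 25000 nM in this assay, at which 1 of the 3 values shown sits. Still open, on these data alone, is whether ethyl, methoxy or chlorine on this aromatic carbon would stay within the scatter, and how a piperidin-1-yl amine part would compare with morpholin-4-yl.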